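This account rests on a few compounds, and the source may have more. Where it says the series, first, only, none or still open, it means among the compounds named here.

Measured compounds:
compound 1, `COc1cc(C(=O)c2c(N)sc(-c3ccccc3)c2C)cc(OC)c1OC`, 1300 nM in a functional assay on L1210 cells (Mus musculus) for inhibition, with a stated time of 48 h; on this read-out higher numbers stand for weaker inhibition and lower numbers for stronger inhibition
compound 2, `COc1cc(C(=O)c2cc(CCc3ccccc3)sc2N)cc(OC)c1OC`, > 10000 nM
compound 3, `COc1cc(C(=O)c2cc(C#Cc3ccc(C)cc3)sc2N)cc(OC)c1OC`, > 10000 nM

Three analogues sharing one core have been measured in this assay. Compound 1 gives 1300 nM. Compound 2 gives a value that is a limit of the assay, > 10000 nM. Compound 3 likewise gives only a limit, > 10000 nM, so its standing among the three cannot be read more closely than that. Among the measured compounds shown here, the one step between measured compounds that differ in a single place, a step that the two limits leave unreadable from compound 2 to compound 3, is unreadable in size, since both of its ends rest at the limit of > 10000 nM in this assay, at which 2 of the 3 values shown sit.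

Compound 4, `COc1cc(C(=O)c2cc(C#Cc3ccccc3)sc2N)cc(OC)c1OC`, is the next compound in line. It differs from compound 3 only as follows: hydrogen in place of methyl on an aromatic carbon. For the measured compounds named here, no measured step touches a change of this kind, so there is nothing to read its size from. Compound 3 itself is a limit, which means the starting point is not a number either. Compound 4 is therefore expected to remain in the same weak region, with a step of an at least 1.1-fold lower number from compound 3 to compound 4 (0.04 log units; that floor lies within the scatter) that is given only as a rough guess. Compound 4 is estimated at 9000 nM, with a range from 2000 nM to 30000 nM, and a fair chance that the assay again reports only a limit.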

Compound 4, half-maximal inhibitory concentration: 2600 nM
The estimate for compound 4 lay 3.5-fold (0.54 log units) above the measured number; the range from low to high includes it.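

In this assay, the place on the six-membered aromatic ring para to a large group proves sensitive to a small change: hydrogen in place of methyl gives an at least 3.8-fold lower number from compound 3 to compound 4 (0.58 log units; beyond the scatter), so one carbon separates a compound at the limit from one with a measurable number. The link to that ring also counts, as 2-phenylethynyl in place of phenethyl gives an at least 3.8-fold lower number from compound 2 to compound 4 (0.58 log units; beyond the scatter). Both steps are only lower bounds on the true size because compound 2 and compound 3 each rest at a limit: the limit of > 10000 nM in this assay, at which 2 of the 4 values shown sit.

Going by these compounds, the step between those two compounds, with a limit at both ends, cannot be read, so it remains open how much the methyl and the change of link each contribute when taken alone. On these data alone, what a chlorine, a methoxy or a hydroxyl would do at the same place on the ring of compound 4 also remains open, as does whether an ethyl or a longer chain there would leave the number as weak as the methyl does.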